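Compound 3 to compound 4: replacing the diethylamino group

A few compounds are considered here, and "the series" means these few. Any claim that something is new, unique, unknown or untested is made for them only; others in the source may bear on it.

In a functional assay on MGC-803 cells (Homo sapiens) for cytotoxicity, read by MTT assay, with a stated time of 48 h (on this read-out lower numbers stand for stronger inhibition and higher numbers for weaker inhibition), compound 1 (`CC1=NN(C(=O)COc2ccc(Cl)cc2)C(c2cc(Br)cc(Br)c2O)C1`) gives 50000 nM and compound 3 (`CCN(CC)CC(=O)N1N=C(C)CC1c1ccccc1O`) gives 39800 nM. These two values lie within the scatter of each other, so compound 3 stands level with compound 1 on the numbers available. Compound 2 (`CC1=NN(S(=O)(=O)c2ccc([N+](=O)[O-])cc2)C(c2cc(Cl)ccc2O)C1`) is reported as "not active" (no number reported), with no number to compare.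

The next compound is compound 4 (`CC1=NN(C(=O)CN2CCC(Cl)CC2)C(c2ccccc2O)C1`). It carries 4-chloropiperidin-1-yl in place of diethylamino on a saturated chain carbon bound to a carbonyl carbon.

Among the compounds with values here, no measured pair differs in one place, so the size of this change cannot be read from the data. Within the data shown here, the only guide is compound 3 itself, at 39800 nM in this assay. No shift beyond the scatter is expected, and no direction can be argued. The expected change is a 1.3-fold lower number from compound 3 to compound 4 (0.12 log units; within the scatter). For compound 4 the estimated value is 30000 nM, with an expected range of 10000 nM to 80000 nM.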

Compound 4, half-maximal inhibitory concentration: 30300 nM
Beside the measured number, compound 4's estimate is 1.0-fold (0.00 log units) below it, and the stated range covers the measured number.
By their numbers in this assay, from the lowest: compounds 4, 3 and 1 (each within the scatter of the next).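

In this assay the series now has its first step that differs in one place: 4-chloropiperidin-1-yl in place of diethylamino on a saturated chain carbon bound to a carbonyl carbon gives a 1.3-fold lower number from compound 3 to compound 4 (0.12 log units; within the scatter). Within the data shown here, on the shared core, this place therefore carries either the open diethylamino group or a six-membered non-aromatic ring bearing chlorine without the read-out leaving the scatter, which the earlier compounds, differing in several places at once, could not show. No measurement at hand speaks to the reason for this outcome.

As far as these compounds go, whether the chlorine itself matters remains open, and piperidin-1-yl on the same chain carbon would separate it from the ring. Also open, from the compounds shown here alone, is how morpholin-4-yl, a primary amine or a carboxylic acid would read in this assay at this place.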